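This account rests on a few compounds, and the source may have more. Where it says the series, first, only, none or still open, it means among the compounds named here.

In a functional assay on SW480 cells (Homo sapiens) for antiproliferative activity, read by MTT assay, with a stated time of 48 h (a lower number here means a stronger inhibitor, a higher number a weaker inhibitor), three compounds with a shared core differ only in a saturated chain. Compound 1 `CCCCCCCCC(CCO)n1cnc2c(N(C)C)ncnc21` gives 21600 nM, compound 2 `CCCCCCCCCC(CCO)n1cnc2c(N(C)C)ncnc21` gives 12200 nM, and compound 3 `CCCCCCCCCCC(CCO)n1cnc2c(N(C)C)ncnc21` gives 3320 nM, the lowest of the three numbers. Compound 4 `CCCCCCCCCCCC(CCO)n1cnc2c(N(C)C)ncnc21` is not yet measured. It differs from compound 3 by methyl in place of hydrogen on a saturated chain carbon, ten or more bonds along the chain from an aromatic nitrogen, which is methyl in place of hydrogen on a saturated chain carbon, ten or more bonds along the chain from an aromatic nitrogen. Two earlier steps of this kind bear on it: a 1.8-fold lower number from compound 1 to compound 2 (0.25 log units; within the scatter) and a 3.7-fold lower number from compound 2 to compound 3 (0.57 log units; beyond the scatter). Across both, the change is a 6.5-fold lower number from compound 1 to compound 3 (0.81 log units; beyond the scatter). A further modest fall in this assay is therefore expected, though three compounds make a thin basis. Compound 4 is estimated at 1500 nM, with an expected range of 600 nM to 3800 nM. The expected step is a 2.2-fold lower number from compound 3 to compound 4 (0.35 log units; beyond the scatter).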

Compound 4, half-maximal inhibitory concentration: 11800 nM
Beside the measured number, compound 4's estimate is 7.9-fold (0.90 log units) below it, and the stated range ends below it.
By their numbers in this assay, from the lowest: compound 3; then compounds 4, 2 and 1 (each within the scatter of the next).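

Lengthening the chain does not keep lowering the number in this assay: on a saturated chain carbon, methyl in place of hydrogen now gives a 3.6-fold higher number from compound 3 to compound 4 (0.55 log units; beyond the scatter). The same change therefore gives different results on different chains: the same change on two cores in this assay, a 1.8-fold lower number (0.25 log units; within the scatter) from compound 1 to compound 2 and a 3.6-fold higher number (0.55 log units; beyond the scatter) from compound 3 to compound 4, 6.3-fold (0.80 log units) apart, beyond the scatter of two such steps The longest chain shown gives back the earlier gain, with a 1.0-fold lower number from compound 2 to compound 4 (0.01 log units; within the scatter) and a 1.8-fold lower number from compound 1 to compound 4 (0.26 log units; within the scatter), which leaves compound 3 alone at the lowest number.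

As far as these compounds go, whether a longer chain would hold this level or raise the number further stays open. So does what an amine in place of methyl would do at this place.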